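The source may report more compounds than this note shows. Statements on the series, on what has been measured and on what is new or still open speak of the compounds shown alone.

Compound 2 `Cc1cccc2c1nc(COc1ccc(Cl)cc1)n2CCCC1CCN(CCCC(=O)O)CC1` gives the highest number of the two measured here, 1630 nM in an assay on AV12 cells for binding affinity to Neuropeptide Y receptor type 1 (Homo sapiens); on this read-out higher numbers stand for weaker inhibition and lower numbers for stronger inhibition. Its nearest neighbour, compound 1 `CCOC(=O)CCCN1CCC(CCCn2c(COc3ccc(Cl)cc3)nc3c(C)cccc32)CC1`, gives 29 nM, and that step is a 56-fold higher number from compound 1 to compound 2 (1.75 log units; beyond the scatter). Compound 3 `Cc1cccc2c1nc(COc1ccc(Cl)cc1)n2CCCC1CCN(C(=O)CCN2CCCCC2)CC1` differs from compound 2 by (2-(piperidin-1-yl)ethyl)carbonyl in place of 3-carboxypropyl on an amine nitrogen in a ring. For the measured compounds named here, the one measured step bears on this change only in part, since it concerns the same ring nitrogen but a different group, yet it shows that removing the free acid can be rewarded. Compound 3 is therefore expected to sit at 60 nM, between 10 nM and 400 nM, a step of a 27-fold lower number from compound 2 to compound 3 (1.43 log units; beyond the scatter).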

Compound 3, inhibition constant: 260 nM
The estimate for compound 3 lay 4.3-fold (0.64 log units) below the measured number; low and high end bracket the measured number.
By their numbers in this assay, from the lowest: compound 1; then compound 3; then compound 2.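

Compound 3 shows that this ring nitrogen tolerates a quite different group from the two chains seen before: (2-(piperidin-1-yl)ethyl)carbonyl in place of 3-carboxypropyl gives a 6.3-fold lower number from compound 2 to compound 3 (0.80 log units; beyond the scatter) in this comparison. Only part of the gap to the ester is closed, as replacing 3-(ethoxycarbonyl)propyl with the same group gives a 9.0-fold higher number from compound 1 to compound 3 (0.95 log units; beyond the scatter) in the matching comparison. No measurement here explains either step.
Still open, as far as these compounds go, is whether a plain acetyl group on this nitrogen, or a 3-(piperidin-1-yl)propyl chain without the carbonyl, would behave like compound 3.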